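Dropping the Ester Chain: Expecting Another Assay Limit

The source may report more compounds than this note shows. Statements on the series, on what has been measured and on what is new or still open speak of the compounds shown alone.

Compound 1 `CN1C(=O)C2(C(C#N)=C(N)Oc3cc4oc(-c5ccccc5)cc(=O)c4c(O)c32)c2ccccc21` and compound 2 `CC(C)(C)OC(=O)CN1C(=O)C2(C(C#N)=C(N)Oc3cc4oc(-c5ccccc5)cc(=O)c4c(O)c32)c2ccccc21` share one core and differ only at the ring amide nitrogen. In a functional assay on K562 cells (Homo sapiens) for antiproliferative activity, read by MTT assay, with a stated time of 48 h (on this read-out higher numbers stand for weaker inhibition and lower numbers for stronger inhibition), compound 1 gives only a limit of the assay, > 50000 nM. In this assay compound 2 likewise gives only a limit, > 50000 nM. The step that the two limits leave unreadable from compound 1 to compound 2 therefore has no readable size, since both values sit at the limit of > 50000 nM in this assay, at which 2 of the 2 values shown sit. Compound 3 `N#CC1=C(N)Oc2cc3oc(-c4ccccc4)cc(=O)c3c(O)c2C12C(=O)Nc1ccccc12` carries the change (hydrogen in place of (tert-butoxycarbonyl)methyl on an amide-type nitrogen in a ring), hydrogen in place of (tert-butoxycarbonyl)methyl on an amide-type nitrogen in a ring. Among the compounds with values here, no measured step gives a direction for this change. Compound 3 is expected to give about 60000 nM, between 15000 nM and 250000 nM, probably again as a limit. The expected step is a step that the limit leaves unreadable from compound 2 to compound 3.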

Compound 3, half-maximal inhibitory concentration: 36400 nM
Compound 3: the middle estimate sits 1.6-fold (0.22 log units) above what was measured; measured number inside the range.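

Within the data shown here, compound 3, which carries the amide hydrogen, is the only one of the three compounds to give a number rather than a limit in this assay: 36400 nM. Replacing (tert-butoxycarbonyl)methyl with hydrogen gives an at least 1.3-fold lower number from compound 2 to compound 3 (0.13 log units; that floor lies within the scatter), and replacing methyl with hydrogen gives an at least 1.3-fold lower number from compound 1 to compound 3 (0.13 log units; that floor lies within the scatter). The true size of these steps stays unknown, and neither shows a real gain, because the other two compounds give only limits: the limit of > 50000 nM in this assay, at which 2 of the 3 values shown sit.

Still open, going by these compounds, is whether a different group on this nitrogen, such as a longer chain ending in an amine or a carboxylic acid, would change the number clearly. The compounds shown also leave open how changes elsewhere on the shared core would act.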